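Swapping Chloro for Iodo on a Triazine Enzyme Inhibitor

This account rests on a few compounds, and the source may have more. Where it says the series, first, only, none or still open, it means among the compounds named here.

Compound 1 `CCc1ccccc1N1C(N)=NC(N)=NC1(C)C`: 4.48
Compound 2 `CC1(C)N=C(N)N=C(N)N1c1ccccc1Cl`: 5.19

Both numbers come from an assay for inhibition of Dihydrofolate reductase (Bos taurus), at pH 7.20; a lower number here means a less potent compound, a higher number a more potent compound, by a factor of ten per unit of this negative logarithm. Going by the values given here, compound 2 stands highest of the two measured compounds, the single measured step being a number 0.71 log units higher from compound 1 to compound 2 (beyond the scatter). Compound 3 `CC1(C)N=C(N)N=C(N)N1c1ccccc1I` differs from compound 2 by iodo in place of chloro on an aromatic carbon. Among the compounds with values here, no measured step mirrors a swap of one halogen for another; the one known step concerns a different change, so only a small shift beyond the scatter, if any, is expected here. Compound 3 is therefore estimated at 5.3, within a range of 4.7 to 5.9, an expected step of a number 0.11 log units higher from compound 2 to compound 3 (within the scatter).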

Compound 3, logarithm of the reciprocal of the active concentration, log(1/C): 3.75
Estimate against measurement, compound 3: 1.55 log units above; measured number outside the range, below it.
By their numbers in this assay, from the lowest: compound 3; then compound 1; then compound 2.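

Iodo in place of chloro gives a number 1.44 log units lower from compound 2 to compound 3 (beyond the scatter) and is the largest step seen so far, so at this place, ortho to a large group, one halogen cannot stand in for another. Iodo also ranks under ethyl, with a number 0.73 log units lower from compound 1 to compound 3 (beyond the scatter) as the step, which puts chloro first, ethyl second and iodo last among these three groups. No measured evidence is available to account for this drop. From the compounds shown here alone, whether bromo or fluoro would track chloro or iodo remains open, as does how a methoxy group or an amine would fare here.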